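Iodo for isopropyl on a second amide chain

The source may report more compounds than this note shows. Statements on the series, on what has been measured and on what is new or still open speak of the compounds shown alone.

Compound 1 `CCCC(=O)Nc1ccc(S(=O)(=O)Oc2ccccc2C(C)C)cc1` gives 950 nM in a functional assay on HT-1080 cells (Homo sapiens) for antiproliferative activity, read by sulforhodamine B assay, with a stated time of 48 h; a higher number here means a weaker inhibitor, a lower number a stronger inhibitor. Compound 2 `CCCC(=O)Nc1ccc(S(=O)(=O)Oc2ccccc2I)cc1` carries the change iodo in place of isopropyl on an aromatic carbon and gives 2000 nM in this assay, a step of a 2.1-fold higher number from compound 1 to compound 2 (0.32 log units; beyond the scatter).

Compound 3 `CC(C)c1ccccc1OS(=O)(=O)c1ccc(NC(=O)CCl)cc1` differs from compound 1 by chloro in place of ethyl on a saturated chain carbon bound to a carbonyl carbon; in this assay compound 3 gives 1000 nM, a step of a 1.1-fold higher number from compound 1 to compound 3 (0.02 log units; within the scatter), so the two cores give numbers within the scatter of each other.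

Compound 4 `O=C(CCl)Nc1ccc(S(=O)(=O)Oc2ccccc2I)cc1` has not yet been measured in this assay. Its difference from compound 3 is iodo in place of isopropyl on an aromatic carbon, the same change as that from compound 1 to compound 2. Since the two cores show no counted difference in behaviour, the step from compound 3 to compound 4 is expected to be about a 2.1-fold higher number from compound 3 to compound 4 (0.32 log units; beyond the scatter), resting on the step of a 2.1-fold higher number from compound 1 to compound 2 (0.32 log units; beyond the scatter). On that basis compound 4 is estimated at 2100 nM in this assay, expected to lie between 1200 nM and 3800 nM.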

Compound 4, half-maximal inhibitory concentration: 600 nM
Compound 4: the middle estimate sits 3.5-fold (0.54 log units) above what was measured; measured number outside the range, below it.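

Carried to the core of compound 3, iodo in place of isopropyl on an aromatic carbon gives a 1.7-fold lower number from compound 3 to compound 4 (0.22 log units; within the scatter) in this assay, and this does not repeat the step seen on the core of compound 1: the same change on two cores in this assay, a 2.1-fold higher number (0.32 log units; beyond the scatter) from compound 1 to compound 2 and a 1.7-fold lower number (0.22 log units; within the scatter) from compound 3 to compound 4, 3.5-fold (0.55 log units) apart, beyond the scatter of two such steps. Read the other way, chloro in place of ethyl gives a 3.3-fold lower number from compound 2 to compound 4 (0.52 log units; beyond the scatter), and this too departs from its counterpart on the other core: the same change on two cores in this assay, a 1.1-fold higher number (0.02 log units; within the scatter) from compound 1 to compound 3 and a 3.3-fold lower number (0.52 log units; beyond the scatter) from compound 2 to compound 4, 3.5-fold (0.55 log units) apart, beyond the scatter of two such steps. Within the data shown here, the two changes therefore do not simply add up across these four compounds, so a step measured on one core did not predict the step on the other; however, each change is seen on only one pair of cores, and the data do not show why the steps differ.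

The compounds shown leave open whether bromo or methoxy on that aromatic carbon would follow iodo or isopropyl. They also leave open how an amine or a longer chain in place of the chloro would behave on either core.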